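A longer bromoalkoxy chain in place of chloro

The compounds below may be only part of what the source reports. "The series", "measured", "known", "first", "only" and "open" are said of these compounds alone.

Measured in a functional assay on HCT-116 cells (Homo sapiens) for antiproliferative activity, read by MTT assay, with a stated time of 48 h; a lower number here means a stronger inhibitor, a higher number a weaker inhibitor:
- compound 1 `COc1ccc(N(C)c2ccnc(Cl)n2)cc1Cl`: 1170 nM
- compound 2 `COc1ccc(N(C)c2ccnc(Cl)n2)cc1[N+](=O)[O-]`: 4700 nM
- compound 3 `COc1ccc(N(C)c2ccnc(Cl)n2)cc1OCCCCBr`: 1140 nM

These three compounds share a core and differ in one group on an aromatic carbon. Compound 1 shares the low end of the numbers with its nearest neighbour, the gap being a 1.0-fold lower number from compound 1 to compound 3 (0.01 log units; within the scatter). Its furthest neighbour lies at a 4.0-fold higher number from compound 1 to compound 2 (0.60 log units; beyond the scatter).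

The unmeasured compound 4 `COc1ccc(N(C)c2ccnc(Cl)n2)cc1OCCCCCBr` comes from compound 1 by one change: (5-bromopentyl)oxy in place of chloro on an aromatic carbon. The (5-bromopentyl)oxy group sits ortho to a methoxy group.

The best guide is the swap of chloro for 4-bromobutoxy at that carbon, the most similar change measured, which gave a 1.0-fold lower number from compound 1 to compound 3 (0.01 log units; within the scatter). The numbers do respond to the group at this carbon, as a 4.1-fold lower number from compound 2 to compound 3 (0.62 log units; beyond the scatter) shows, so a change here cannot be assumed harmless. For the measured compounds named here, still, no compound with the (5-bromopentyl)oxy group has been measured, so the range must stay wide.

No step beyond the scatter is expected in this assay. The estimated step is a 1.1-fold lower number from compound 1 to compound 4 (0.03 log units; within the scatter). For compound 4 the expected value is 1100 nM. The estimated range runs from 500 nM to 2500 nM.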

Compound 4, half-maximal inhibitory concentration: > 10000 nM
Compound 4: only a limit was reported; the forecaster's own chance of this, stated with the estimate: 3%; middle value at least 9.0-fold (0.95 log units) away from the limit.
By their numbers in this assay, from the lowest: compounds 3 and 1 (each within the scatter of the next); then compound 2. At a limit, above all of these: compound 4.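

In this assay compound 4 gives > 10000 nM, which is a limit of the assay and not an exact number: the limit of > 10000 nM in this assay, at which 1 of the 4 values shown sits.

Going from the 4-bromobutoxy chain to the (5-bromopentyl)oxy chain gives an at least 8.7-fold higher number from compound 3 to compound 4 (0.94 log units; beyond the scatter), so at this carbon the outcome depends strongly on chain length, a dependence the earlier compounds could not reveal. The same change from the smaller groups, seen in an at least 8.5-fold higher number from compound 1 to compound 4 (0.93 log units; beyond the scatter) and an at least 2.1-fold higher number from compound 2 to compound 4 (0.32 log units; beyond the scatter), shows that the match between the chloro and 4-bromobutoxy compounds does not extend to every bromoalkoxy chain, and that the (5-bromopentyl)oxy compound falls even beyond the nitro compound, previously the highest number of the set.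

Two chain lengths cannot show whether the numbers would stay high with a longer chain or whether a shorter chain would match the 4-bromobutoxy compound. Going by these compounds, it also remains open whether the terminal bromine matters, which a plain pentyloxy chain, or a chain of the same length ending in an amine or a hydroxyl group, could help to settle.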